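The source may hold more compounds than are shown below. What is called first, only, known or untested is meant among the compounds shown, and "the series" means these compounds.

Compound 1, `Cc1ccc(-c2cc3occ(C)c3c(=O)o2)cc1`; compound 2, `Cc1ccc(-c2cc3occ(C)c3c(=O)o2)cc1C`; compound 3, `COc1cc(OC)cc(-c2cc3occ(C)c3c(=O)o2)c1`.

In a functional assay on SK-BR-3 cells (Homo sapiens) for cytotoxicity, read by sulforhodamine B assay, with a stated time of 72 h (a lower number here means that less compound is needed, a higher number that more compound is needed for the effect), compound 1 gives > 83.3 uM, which is a limit of the assay and not a number. Compound 2 gives 14.6 uM and compound 3 gives 0.28 uM. The change from compound 1 to compound 2, (methyl in place of hydrogen on an aromatic carbon), brings an at least 5.7-fold lower number from compound 1 to compound 2 (0.75 log units; beyond the scatter); its size rests on (the limit of > 83.3 uM in this assay, at which 1 of the 3 values shown sits). The difference between the cores of compound 1 and compound 3 is not broken down here. Compound 4, `COc1cc(OC)cc(-c2cc3oc(C)c(C)c3c(=O)o2)c1`, is not yet measured. It differs from compound 3 by methyl in place of hydrogen on an aromatic carbon, the same kind of change, but here the methyl stands on a five-membered aromatic ring with one oxygen, part of a fused system of two rings, next to the ring oxygen and next to the ring atom that bears a methyl group, whereas in compound 2 it stands on a six-membered aromatic ring of carbon only, ortho to a methyl group and meta to a large group. For compound 4 the expected step in this assay is a 1.1-fold lower number from compound 3 to compound 4 (0.05 log units; within the scatter). That is set smaller than an at least 5.7-fold lower number from compound 1 to compound 2 (0.75 log units; beyond the scatter), as the two places are not the same. The estimate for compound 4 is 0.25 uM, expected between 0.08 uM and 0.8 uM.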

Compound 4, concentration for half-maximal effect: > 66.7 uM
Compound 4 ended at the assay's limit; the forecaster's own chance of this, stated with the estimate: 2%; at least 260-fold (2.42 log units) between middle value and limit.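

In this assay, methyl in place of hydrogen on an aromatic carbon brings an at least 230-fold higher number from compound 3 to compound 4 (2.37 log units; beyond the scatter). Carried from one core to another, this change keeps neither its direction nor its size, but the two methyl groups also stand in different places, so the compounds cannot separate the role of the core from that of the place: the same change on two cores in this assay, an at least 5.7-fold lower number (0.75 log units; beyond the scatter) from compound 1 to compound 2 and an at least 230-fold higher number (2.37 log units; beyond the scatter) from compound 3 to compound 4, at least 1300-fold (3.13 log units) apart, beyond the scatter of two such steps Compound 4 gives > 66.7 uM, which is a limit of the assay and not a number, so the true size of its step stays unknown: the limit of > 66.7 uM in this assay, at which 1 of the 4 values shown sits.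

The compounds shown leave open whether an ethyl group, a chlorine or an amine at the same place would give a similar result. They also leave open how the same methyl at that place would act on the core of compound 1.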